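Ethoxy to propoxy: one more carbon on the chain

The compounds below may be only part of what the source reports. "The series", "measured", "known", "first", "only" and "open" are said of these compounds alone.

Compound 1 `CCCOC(=O)N1N=C(c2ccccc2)CC1c1cc(OC)c(OC)c(OC)c1` gives > 10000 nM (a limit)
Compound 2 `COC(=O)N1N=C(c2cccc(OC)c2)CC1c1cc(OC)c(OC)c(OC)c1` gives 1300 nM
Compound 3 `CCOC(=O)N1N=C(c2cccc(OC)c2)CC1c1cc(OC)c(OC)c(OC)c1` gives 7860 nM

All three were tested in a functional assay on HT-29 cells (Homo sapiens) for antiproliferative activity, read by MTT assay, with a stated time of 48 h; a lower number here means a stronger inhibitor of growth, a higher number a weaker inhibitor of growth. For compound 1 there is only a limit of the assay, not a number. Of the two true numbers, the higher belongs to compound 3 at 7860 nM, so it is the weaker inhibitor of that pair.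

Compound 4 `CCCOC(=O)N1N=C(c2cccc(OC)c2)CC1c1cc(OC)c(OC)c(OC)c1` differs from compound 3 in one place: methyl in place of hydrogen on a saturated chain carbon, two bonds along the chain from an oxygen next to a carbonyl group. This is methyl in place of hydrogen on a saturated chain carbon, two bonds along the chain from an oxygen next to a carbonyl group, or ethoxy to propoxy.

Among the compounds with values here, one measured step bears on this, the same swap on the chain carbon bound to that oxygen: a 6.0-fold higher number from compound 2 to compound 3 (0.78 log units; beyond the scatter). A single step is a guide, not a rule, but it points to a further rise in this assay, probably a smaller one. Compound 4 may itself return only a limit.

The expected change is a 1.8-fold higher number from compound 3 to compound 4 (0.25 log units; within the scatter). For compound 4 the estimated value is 14000 nM, with an expected range from 5000 nM to 40000 nM.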

Compound 4, concentration for 50% growth inhibition: > 10000 nM
Compound 4: only a limit was reported; the forecaster's own chance of this, stated with the estimate: 60%; the middle value does not contradict the limit.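

In this assay compound 4 returns only a limit, and compound 1 shares that limit: the limit of > 10000 nM in this assay, at which 2 of the 4 values shown sit. Because a limit is not a number, the step from ethoxy to propoxy survives only as a floor, an at least 1.2-fold higher number from compound 3 to compound 4 (0.10 log units; that floor lies within the scatter), and that floor alone does not show that the extra carbon costs any activity. Measured from the methoxy ester, the loss is clear, an at least 7.6-fold higher number from compound 2 to compound 4 (0.88 log units; beyond the scatter), so among compound 2, compound 3 and compound 4 a longer chain on this oxygen never brings a lower number.

Compound 1 and compound 4 are both limits, so the step between them cannot be read, and the effect of the methoxy group on the aromatic ring stays hidden at this chain length. Going by these compounds, whether a butoxy chain, or an amine at the end of the chain, would bring growth inhibition back into a measurable range remains open.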